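The source may report more compounds than this note shows. Statements on the series, on what has been measured and on what is new or still open speak of the compounds shown alone.

Measured in a functional assay on HeLa cells (Homo sapiens) for cytotoxicity, read by resazurin assay, with a stated time of 72 h; a lower number here means a stronger inhibitor, a higher number a weaker inhibitor:

- Compound 1 `COCCSC(=S)SCC(=O)c1ccc(OC)cc1`: 7880 nM
- Compound 2 `CCCC(=S)SCC(=O)c1ccc(OC)cc1`: 5710 nM
- Compound 3 `CCNC(=O)SCC(=O)c1ccc(OC)cc1`: 13300 nM

Compound 3 lies within the scatter of compound 1. The measured step that sets it apart from the rest of the set is a 2.3-fold higher number from compound 2 to compound 3 (0.37 log units; beyond the scatter).

The next compound, compound 4 `CCNC(=S)SCC(=O)c1ccc(OC)cc1`, loses the ethylcarbamoyl group on a sulfur whose other neighbours are a saturated chain carbon: a group of 5 heavy atoms (3 carbon, 1 nitrogen, 1 sulfur; no ring) in place of a group of 5 heavy atoms (3 carbon, 1 nitrogen, 1 oxygen; no ring), on a sulfur. The entering group holds sulfur where the leaving group holds oxygen, and the rest of the molecule is unchanged.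

Within the data shown here, no measured step isolates this exchange. The closest evidence is a 2.3-fold higher number from compound 2 to compound 3 (0.37 log units; beyond the scatter), a modest step that also changes the rest of the group. Between the two compounds with a thiocarbonyl carbon, the change was a 1.4-fold lower number from compound 1 to compound 2 (0.14 log units; within the scatter), so the group on that carbon has made little measurable difference so far. Compound 4 also has a thiocarbonyl carbon, so it is expected to sit near compound 1 at 7880 nM and compound 2 at 5710 nM. A modest move in this assay towards a lower number is therefore expected, close to the edge of the scatter.

The estimate amounts to an expected 2.0-fold lower number from compound 3 to compound 4 (0.29 log units; within the scatter).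

For compound 4 the estimated value is 6800 nM, with an expected range of 3000 nM to 14000 nM.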

Compound 4, half-maximal inhibitory concentration: 7800 nM
Beside the measured number, compound 4's estimate is 1.1-fold (0.06 log units) below it, within the range that was stated.
By their numbers in this assay, from the lowest: compounds 2, 4, 1 and 3 (each within the scatter of the next, the first and the last beyond it).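

In this assay, placing sulfur where the ethylcarbamoyl group holds oxygen, with the ethylamino part unchanged, gives a 1.7-fold lower number from compound 3 to compound 4 (0.23 log units; within the scatter) and so does not separate the two compounds. On the thiocarbonyl carbon, ethylamino can so far not be told apart from the two earlier groups: exchanging propyl for it gives a 1.4-fold higher number from compound 2 to compound 4 (0.14 log units; within the scatter) and exchanging (2-methoxyethyl)sulfanyl for it gives a 1.0-fold lower number from compound 1 to compound 4 (0.00 log units; within the scatter) in the same assay. The earlier 2.3-fold higher number from compound 2 to compound 3 (0.37 log units; beyond the scatter) now divides into two single exchanges through compound 4, each within the scatter, so neither exchange alone accounts for that larger step. Nothing given here explains these results.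

The compounds shown leave open whether any group on the thiocarbonyl carbon can move the number beyond the scatter, for instance a piperidine ring, a carboxylic acid or a much longer alkyl chain. They also leave open whether the same exchange of oxygen for sulfur would give a similar result with propyl or (2-methoxyethyl)sulfanyl in place of ethylamino.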